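Working notes: chloro to methoxy on the series

A few compounds are considered here, and "the series" means these few. Any claim that something is new, unique, unknown or untested is made for them only; others in the source may bear on it.

Measured so far in a functional assay on HL-60 cells (Homo sapiens) for cytotoxicity, with a stated time of 24 h; a higher number here means that more compound is tolerated, a lower number that less compound is tolerated 
compound 1 `O=C1/C(=C/c2ccc(Cl)cc2)CCC/C1=C\c1ccccc1[N+](=O)[O-]` gives 7600 nM 
compound 2 `O=C1/C(=C/c2ccc(F)cc2)CCC/C1=C\c1ccc([N+](=O)[O-])cc1` gives 32000 nM 
compound 3 `O=C1/C(=C/c2ccc(Cl)cc2)CCC/C1=C\c1ccc([N+](=O)[O-])cc1` gives 4100 nM 

Compound 3 at 4100 nM and compound 1 at 7600 nM lie within the scatter of each other, so these two values cannot be ranked. Among the measured compounds shown here, compound 2 stands apart, with a 7.8-fold lower number from compound 2 to compound 3 (0.89 log units; beyond the scatter) as the only measured step that differs in one place. That step is modest in size and beyond the scatter, and it is chloro in place of fluoro on an aromatic carbon.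

Compound 4 `COc1ccc(/C=C2\CCC/C(=C\c3ccc([N+](=O)[O-])cc3)C2=O)cc1` has not been measured. Its difference from compound 3 is methoxy in place of chloro on an aromatic carbon and reads as methoxy in place of chloro on an aromatic carbon, para to a large group, or 4-chlorophenyl to 4-methoxyphenyl.

For the measured compounds named here, no measured compound carries methoxy, so a 7.8-fold lower number from compound 2 to compound 3 (0.89 log units; beyond the scatter) is only a loose guide to size, and the direction is uncertain. A modest move to a higher number in this assay is expected, no larger than that halogen step. The expected step is a 2.2-fold higher number from compound 3 to compound 4 (0.34 log units; beyond the scatter) on this reading. Compound 4 is estimated at 9000 nM with an expected range of 3000 nM to 30000 nM for now.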

Compound 4, half-maximal cytotoxic concentration: > 400000 nM
Compound 4: no number, only a limit; the forecaster's own chance of this, stated with the estimate: 3%; middle value at least 44-fold (1.64 log units) away from the limit.
By their numbers in this assay, from the lowest: compounds 3 and 1 (each within the scatter of the next); then compound 2. At a limit, above all of these: compound 4.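

In this assay compound 4 gives > 400000 nM, which is a limit of the assay and not a number: the limit of > 400000 nM in this assay, at which 1 of the 4 values shown sits. At this place, on an aromatic carbon para to a large group, methoxy in place of chloro gives an at least 97-fold higher number from compound 3 to compound 4 (1.98 log units; beyond the scatter), and methoxy in place of fluoro gives an at least 12-fold higher number from compound 2 to compound 4 (1.09 log units; beyond the scatter). Among the compounds shown here, the only earlier step at this place, a 7.8-fold lower number from compound 2 to compound 3 (0.89 log units; beyond the scatter), was a modest one between two halogens and gave no sign that a single change here could take the number so far in this assay, with both steps into methoxy large and running the opposite way.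

With only chloro, fluoro and methoxy shown at this place, it remains open whether the large step belongs to methoxy itself or would also appear with a methyl, a hydroxyl or an amine there. Also open, as far as these compounds go, is how far the number really rises with methoxy, and whether the same change would give a step of similar size with the nitro group placed as in compound 1.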